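Swapping the triazole of compound 1 for a larger ring

The source may report more compounds than this note shows. Statements on the series, on what has been measured and on what is new or still open speak of the compounds shown alone.

Compound 1 `CC(C)C(c1nnc[nH]1)c1ccc(-c2ccc3cccc(F)c3c2)[nH]c1=O` carries a 4H-1,2,4-triazol-3-yl group on a saturated chain carbon bound to an aromatic carbon and a saturated chain carbon. In an ADME assay on microsomes from liver (Rattus norvegicus) for metabolic stability (on this read-out lower numbers stand for a shorter-lived compound and higher numbers for a longer-lived compound), compound 1 gives 0.552 h, the highest of the three numbers in hand, although both of its neighbours lie within the scatter of it. Compound 2 `CC(C)C(c1ccc(-c2ccc3cccc(F)c3c2)[nH]c1=O)N1CCNC1=O` gives 0.283 h in this assay, and compound 3 `CC(C)C(/C=C1\CCNC1=O)c1ccc(-c2ccc3cccc(F)c3c2)[nH]c1=O` gives 0.345 h. The steps observed are a 2.0-fold lower number from compound 1 to compound 2 (0.29 log units; within the scatter) and a 1.6-fold lower number from compound 1 to compound 3 (0.20 log units; within the scatter), while between the two replacement rings the step is a 1.2-fold higher number from compound 2 to compound 3 (0.09 log units; within the scatter).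

Compound 4 `CC(C)C(c1ccc(-c2ccc3cccc(F)c3c2)[nH]c1=O)N1CCN/C1=N\C#N` has not yet been measured. It differs from compound 1 as follows: a group of 8 heavy atoms (4 carbon, 4 nitrogen; one five-membered non-aromatic ring with 2 hetero atoms) in place of a group of 5 heavy atoms (2 carbon, 3 nitrogen; one five-membered aromatic ring with 3 hetero atoms), on a saturated chain carbon bound to an aromatic carbon and a saturated chain carbon. Within the data shown here, the closest precedent is compound 2, where a five-membered non-aromatic ring with two hetero atoms likewise took the place of the triazole, and that move stayed within the scatter. Nothing among the three measured steps points beyond the scatter in either direction. Compound 4 is therefore expected to show a 1.7-fold lower number from compound 1 to compound 4 (0.24 log units; within the scatter), a step no larger than the usual spread. The estimate for compound 4 in this assay is 0.32 h, with a range from 0.16 h to 0.64 h.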

Compound 4, half-life: 0.327 h
Compound 4: the middle estimate sits 1.0-fold (0.01 log units) below what was measured, and the stated range covers the measured number.
By their numbers in this assay, from the lowest: compounds 2, 4, 3 and 1 (each within the scatter of the next).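

With a third replacement ring on the saturated chain carbon bound to an aromatic carbon and a saturated chain carbon, the read-out in this assay still stays within the scatter: the change gives a 1.7-fold lower number from compound 1 to compound 4 (0.23 log units; within the scatter), and the comparisons with the other two rings give a 1.2-fold higher number from compound 2 to compound 4 (0.06 log units; within the scatter) and a 1.1-fold lower number from compound 3 to compound 4 (0.02 log units; within the scatter). Among these compounds, the position has now carried a group of 8 heavy atoms, with 1 double bond and 1 triple bond outside aromatic rings, and no step among the four compounds goes beyond the scatter, so the larger group does not set compound 4 apart from compound 1, compound 2 or compound 3. Nothing measured here explains why these four groups give such closely matched numbers.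

All of the groups shown at this position are five-membered rings, so it remains open whether a primary amine, a carboxylic acid or an open alkyl chain in their place would move the number beyond the scatter. Equally open, as far as these compounds go, is whether changes elsewhere on the shared core would produce a step beyond the scatter, which none of the changes at this position has done.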